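Sulfonyl aryl replacement: from benzothiophene to bithiophene

The source may hold more compounds than are shown below. What is called first, only, known or untested is meant among the compounds shown, and "the series" means these compounds.

Among the compounds with values here, compound 2 `CCN(C/C=C/C#CC(C)(C)C)Cc1cccc(OCCN(C)S(=O)(=O)c2cc3ccccc3s2)c1` gives the highest of the two numbers known in a functional assay on HepG2 cells for inhibition of squalene monooxygenase (Homo sapiens); on this read-out lower numbers stand for stronger inhibition and higher numbers for weaker inhibition; in this assay compound 2 gives 1800 nM. Its nearest neighbour is compound 1 `CCN(C/C=C/C#CC(C)(C)C)Cc1cccc(OCCN(C)S(=O)(=O)c2ccc(C#N)cc2)c1`, which in this assay gives 200 nM. Compound 3 `CCN(C/C=C/C#CC(C)(C)C)Cc1cccc(OCCN(C)S(=O)(=O)c2cc(-c3ccsc3)cs2)c1` differs from compound 2 by 4-(thiophen-3-yl)thiophen-2-yl in place of 1-benzothiophen-2-yl on a sulfonyl sulfur. Within the data shown here, the only step that bears on this position is a 9.0-fold higher number from compound 1 to compound 2 (0.95 log units; beyond the scatter), a swap of the aryl group on the same sulfonyl sulfur. That step does not indicate the direction for a second bicyclic-to-bithiophene change, so for compound 3 a step of a 1.2-fold lower number from compound 2 to compound 3 (0.08 log units; within the scatter) is expected. Compound 3 is estimated at 1500 nM, within 300 nM to 6000 nM.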

Compound 3, half-maximal inhibitory concentration: 90 nM
Beside the measured number, compound 3's estimate is 17-fold (1.22 log units) above it, and the stated range ends above it.
By their numbers in this assay, from the lowest: compound 3; then compound 1; then compound 2.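

In this assay, the group on the sulfonyl sulfur can lower the number as well as raise it: 4-(thiophen-3-yl)thiophen-2-yl in place of 1-benzothiophen-2-yl gives a 20-fold lower number from compound 2 to compound 3 (1.30 log units; beyond the scatter). The same group also improves on 4-cyanophenyl, with a 2.2-fold lower number from compound 1 to compound 3 (0.35 log units; beyond the scatter), which makes compound 3 the strongest of the three. Nothing available explains this gain.

From the compounds shown here alone, whether both thiophene rings are needed remains open. So does whether a single thiophen-2-yl, or a phenyl carrying an amine or a carboxylic acid, would keep the gain on this sulfonyl sulfur.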